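This account rests on a few compounds, and the source may have more. Where it says the series, first, only, none or still open, it means among the compounds named here.

Measured compounds in a functional assay on the whole organism (Tail, strain ICR) with Mus musculus as the target, in the tail flick test, with a stated time of 30 min, at a dose of 25 umol/kg by the oral route; on this read-out lower numbers stand for a weaker effect and higher numbers for a stronger effect at the one dose given:
- compound 1 `O=C(CN(c1nc(Cl)nc2[nH]cnc12)C1CC1)N[C@@H](CO)C(=O)OCc1ccccc1`: 31.9%
- compound 2 `O=C(CN(c1nc(Cl)nc2[nH]cnc12)C1CC1)N[C@@H](CC(=O)OCc1ccccc1)C(=O)OCc1ccccc1`: 34.7%
- compound 3 `CSCC[C@H](NC(=O)CN(c1nc(Cl)nc2[nH]cnc12)C1CC1)C(=O)OCc1ccccc1`: 22.2%

Compound 3 stands lowest of the three numbers. Its nearest neighbour is compound 1, and the step of a number 9.7 percentage points lower from compound 1 to compound 3 (within the scatter) lies within the scatter; the step of a number 12.5 percentage points lower from compound 2 to compound 3 (beyond the scatter) lies beyond it and is modest. The remaining step, a number 2.8 percentage points higher from compound 1 to compound 2 (within the scatter), lies within the scatter.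

The next compound, compound 4 `CC(C)C[C@H](NC(=O)CN(c1nc(Cl)nc2[nH]cnc12)C1CC1)C(=O)OCc1ccccc1`, keeps the shared core and differs from compound 3 in one place:
isopropyl in place of (methylsulfanyl)methyl on a saturated chain carbon, two bonds along the chain from an amide-type nitrogen and a carbonyl carbon

Among the measured compounds shown here, no measured step introduces isopropyl, so none bears directly on this change. The three steps among compounds 1, 2 and 3 all replace one group with another at the same saturated chain carbon, and only one of them, from compound 2 to compound 3, moved the read-out beyond the scatter, and that modestly. On that basis the step of a number 2.8 percentage points higher from compound 3 to compound 4 (within the scatter) is expected to be small, most likely within the scatter, with no clear direction. For compound 4 the number in this assay is estimated at 25%, with a range from 14% to 40%.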

Compound 4, a percentage reported as activity, at one dose (the size of the read-out at that dose, not a potency): 33.9%
For compound 4 the middle estimate is 8.9 percentage points below the measured one; measured number inside the range.
By their numbers in this assay, from the lowest: compounds 3, 1, 4 and 2 (each within the scatter of the next, the first and the last beyond it).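

In this assay, the change at this saturated chain carbon gives a number 11.7 percentage points higher from compound 3 to compound 4 (beyond the scatter), the second step beyond the scatter at this place, and like the first it has compound 3 at its lower end. Isopropyl cannot be told apart from the two other groups, as the steps of a number 0.8 percentage points lower from compound 2 to compound 4 (within the scatter) and a number 2 percentage points higher from compound 1 to compound 4 (within the scatter) show, so hydroxy, benzyloxycarbonyl and isopropyl now form a set of three whose numbers all lie within the scatter of each other, while compound 3 with its (methylsulfanyl)methyl is set apart from compound 2 and compound 4 but not from compound 1. Nothing measured here accounts for this placing of compound 3.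

On these data alone, whether an amine, a carboxylic acid or a longer alkyl chain on this same chain carbon would stay within that set or move away from it remains open. Each compound is also shown at only one dose and one time, so how they would compare at other doses or times remains open as well.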